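Cytotoxicity of a Methyl-Extended Ether Analogue

The compounds below may be only part of what the source reports. "The series", "measured", "known", "first", "only" and "open" are said of these compounds alone.

Compound 1 `CC(C)CCn1nc(-c2cccs2)c(O)c(C2=NS(=O)(=O)c3ccccc3N2)c1=O` was tested in an ADME assay on Huh-7 cells (Homo sapiens) for cytotoxicity, with a stated time of 72 h; on this read-out higher numbers stand for lower toxicity in this test and lower numbers for higher toxicity in this test. In this assay compound 1 gives > 33000 nM, which is a limit of the assay rather than a number. Compound 2 `CC(C)CCn1nc(-c2cccs2)c(O)c(C2=NS(=O)(=O)c3cc(O)ccc3N2)c1=O` carries hydroxy in place of hydrogen on an aromatic carbon; in this assay compound 2 gives > 25000 nM, again only a limit. Within the data shown here, compound 3 `CC(C)CCn1nc(-c2cccs2)c(O)c(C2=NS(=O)(=O)c3cc(OCC(N)=O)ccc3N2)c1=O` carries carbamoylmethoxy in place of hydrogen on an aromatic carbon, and in this assay compound 3 gives 78000 nM, the only actual number among the three values shown. Because the other two values are limits, the limit of > 25000 nM in this assay, at which 1 of the 3 values shown sits, and the limit of > 33000 nM in this assay, at which 1 of the 3 values shown sits, leave the steps a step that the two limits leave unreadable from compound 1 to compound 2, a step that the limit leaves unreadable from compound 1 to compound 3 and a step that the limit leaves unreadable from compound 2 to compound 3 unreadable in size. Compound 4 `CC(C)CCn1nc(-c2cccs2)c(O)c(C2=NS(=O)(=O)c3cc(OC(C)C(N)=O)ccc3N2)c1=O` differs from compound 3 by methyl in place of hydrogen on a saturated chain carbon bound to a carbonyl carbon and an oxygen on an aromatic ring. Among the measured compounds shown here, no measured step speaks to this change, so no step beyond the usual scatter is expected in this assay, no change at the digits printed from compound 3 to compound 4 (within the scatter). Compound 4 is therefore estimated at 78000 nM, within a range from 30000 nM to 200000 nM.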

Compound 4, half-maximal cytotoxic concentration: 68000 nM
Estimate against measurement, compound 4: 1.1-fold (0.06 log units) above; the range from low to high includes it.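

In this assay the series now has its first step of readable size: a 1.1-fold lower number from compound 3 to compound 4 (0.06 log units; within the scatter). Turning carbamoylmethoxy into 1-carbamoylethoxy thus puts a methyl on this saturated chain carbon with no shift beyond the usual scatter of the cytotoxicity read-out. The steps from compound 1 and from compound 2 to compound 4 cannot be read, as the values of compound 1 and compound 2 are limits and not numbers. Still open, going by these compounds, is whether a longer chain on this carbon, or a carboxylic acid in place of the carbamoyl group, would move the value.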